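Thiophen-2-yl in place of phenyl on the shared core

The source may hold more compounds than are shown below. What is called first, only, known or untested is meant among the compounds shown, and "the series" means these compounds.

Measured so far in a functional assay on NCI-H460 cells (Homo sapiens) for inhibition, with a stated time of 72 h (on this read-out higher numbers stand for weaker inhibition and lower numbers for stronger inhibition), for the shared core:
- compound 1 `COc1ccc(S(=O)(=O)N2CCc3cccc(-c4ccc(F)nc4)c32)cc1` gives 135 nM
- compound 2 `COc1ccc(S(=O)(=O)N2CCc3cccc(-c4ccc(F)cc4)c32)cc1` gives 95.5 nM
- compound 3 `COc1ccc(S(=O)(=O)N2CCc3cccc(-c4ccccc4)c32)cc1` gives 213 nM

Compound 3 lies within the scatter of compound 1 and beyond the scatter from compound 2, whose number is lower. Compound 4 `COc1ccc(S(=O)(=O)N2CCc3cccc(-c4cccs4)c32)cc1` has not yet been measured. It carries thiophen-2-yl in place of phenyl on an aromatic carbon and so differs from compound 3 in that one group.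

Among the measured compounds shown here, no measured step makes this exact exchange. Two measured exchanges of one aromatic ring for another stay within the scatter (a 1.4-fold lower number from compound 1 to compound 2 (0.15 log units; within the scatter) and a 1.6-fold higher number from compound 1 to compound 3 (0.20 log units; within the scatter)). Hydrogen in place of fluoro goes beyond it only modestly (a 2.2-fold higher number from compound 2 to compound 3 (0.35 log units; beyond the scatter)). On the strength of these steps, no clear shift in either direction is expected in this assay for the new exchange. The estimated step is a 1.2-fold lower number from compound 3 to compound 4 (0.07 log units; within the scatter) and it is expected to stay small. Compound 4 is expected at an estimated 180 nM (range 80 nM to 400 nM).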

Compound 4, half-maximal inhibitory concentration: 229 nM
Compound 4: middle estimate off by 1.3-fold (0.10 log units), on the low side; the measured number falls inside the stated range.
By their numbers in this assay, from the lowest: compounds 2, 1, 3 and 4 (each within the scatter of the next, the first and the last beyond it).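

In this assay, this place on the six-membered aromatic ring accepts a five-membered aromatic ring with one sulfur atom as readily as phenyl, with a 1.1-fold higher number from compound 3 to compound 4 (0.03 log units; within the scatter). Exchanging 6-fluoropyridin-3-yl for thiophen-2-yl also stays within the scatter, with a 1.7-fold higher number from compound 1 to compound 4 (0.23 log units; within the scatter), whereas exchanging 4-fluorophenyl for thiophen-2-yl goes beyond it, though only modestly, with a 2.4-fold higher number from compound 2 to compound 4 (0.38 log units; beyond the scatter). Compound 4 thus falls with compound 3 on the same side of compound 2, and no data are available to explain this result.

The compounds shown leave open whether a fluoro on the thiophen-2-yl ring would lower the number, as 4-fluorophenyl does against phenyl. They also leave open whether a non-aromatic group here, such as a morpholine or a carboxylic acid, would keep it in this range.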